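The compounds below may be only part of what the source reports. "The series", "measured", "known", "first", "only" and "open" are said of these compounds alone.

Within the data shown here, in a functional assay on cells (Endothelial cell) for inhibition (a lower number here means a stronger inhibitor, a higher number a weaker inhibitor), compound 2 (`CC(C)(C)c1cc(-c2cc(=O)c3ccc(O)cc3o2)cc(C(C)(C)C)c1O`) gives 2000 nM and stands highest of the two numbers measured so far, with compound 1 (`CCOC(=O)COc1ccc2c(=O)cc(-c3cc(C(C)(C)C)c(O)c(C(C)(C)C)c3)oc2c1`) at 800 nM as its only neighbour. Compound 3 (`CCCCCCOc1ccc2c(=O)cc(-c3cc(C(C)(C)C)c(O)c(C(C)(C)C)c3)oc2c1`) has hexyl in place of hydrogen on an oxygen on an aromatic ring, and no measurement exists for it yet. Among the measured compounds shown here, only one measured step bears on this oxygen, namely a 2.5-fold higher number from compound 1 to compound 2 (0.40 log units; beyond the scatter) with hydrogen replacing (ethoxycarbonyl)methyl. That step is modest but beyond the scatter. Read in reverse, it points to a modest fall in the number when the hydrogen is replaced, although hexyl is a different group and a single step is thin support. The estimated change is a 2.2-fold lower number from compound 2 to compound 3 (0.35 log units; beyond the scatter) and no larger move is expected. In this assay compound 3 is expected at 900 nM with an estimated range from 300 nM to 2500 nM for now.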

Compound 3, half-maximal inhibitory concentration: 50000 nM
The estimate for compound 3 lay 56-fold (1.74 log units) below the measured number; measured number outside the range, above it.
By their numbers in this assay, from the lowest: compound 1; then compound 2; then compound 3.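

Among these compounds, on the oxygen on an aromatic ring, this assay shows that the effect of replacing hydrogen depends strongly on the group that enters, and the earlier compounds gave no sign of this: hexyl produces a 25-fold higher number from compound 2 to compound 3 (1.40 log units; beyond the scatter), whereas (ethoxycarbonyl)methyl gave a lower number than hydrogen. The two ethers also sit far apart, with pentyl in place of ethoxycarbonyl on the saturated chain carbon giving a 63-fold higher number from compound 1 to compound 3 (1.80 log units; beyond the scatter), so substitution on this oxygen does not by itself set the outcome. No supporting data explain this divergence.

Three compounds cannot show whether the rise follows chain length or the absence of the ester. A shorter chain such as ethyl, or a carboxylic acid or an amine at the chain end, would help separate these readings.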